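Cyclohexyl to Benzyl: What Toxicity to Expect

The compounds below may be only part of what the source reports. "The series", "measured", "known", "first", "only" and "open" are said of these compounds alone.

Compound 1, `CCC1(Cc2ccccc2)OS(=O)(=O)C=C1OCC1CCCCC1`, was tested in an ADME assay on HEL cells (Homo sapiens) for cytotoxicity, with a stated time of 3 days; on this read-out higher numbers stand for lower toxicity in this test and lower numbers for higher toxicity in this test. In this assay compound 1 gives > 200000 nM, which is a limit of the assay rather than a number. Compound 2, `CCC1(Cc2ccccc2)OS(=O)(=O)C=C1NCc1ccccc1`, gives 92000 nM in this assay. The step of an at least 2.1-fold lower number from compound 1 to compound 2 (0.33 log units; beyond the scatter) shows that benzylamino in place of cyclohexylmethoxy on a double-bonded ring carbon lowered the number. Compound 3, `CCC1(Cc2ccccc2)OS(=O)(=O)C=C1OCCCCCCc1ccccc1`, reads < 200000 nM in this assay, again a limit. The unmeasured compound 4, `CCC1(Cc2ccccc2)OS(=O)(=O)C=C1OCCc1ccccc1`, differs from compound 1 by benzyl in place of cyclohexyl on a saturated chain carbon bound to an oxygen on an unsaturated carbon. Given the step of an at least 2.1-fold lower number from compound 1 to compound 2 (0.33 log units; beyond the scatter) and the limit of < 200000 nM in this assay, at which 1 of the 3 values shown sits, reached by compound 3, compound 4 is expected to give 140000 nM, between 60000 nM and 300000 nM. The expected step of an at least 1.4-fold lower number from compound 1 to compound 4 (0.15 log units; that floor lies within the scatter) is modest and downward.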

Compound 4, half-maximal cytotoxic concentration: 48000 nM
The estimate for compound 4 lay 2.9-fold (0.46 log units) above the measured number; measured number below the stated range.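

Benzyl in place of cyclohexyl on a saturated chain carbon bound to an oxygen on an unsaturated carbon gives, in this assay, an at least 4.1-fold lower number from compound 1 to compound 4 (0.61 log units; beyond the scatter). With the oxygen kept, changing the end of the side chain from a non-aromatic ring to an aromatic one is thus enough to shift the read-out towards higher toxicity, which compound 2 could not show, since its benzylamino group also replaces that oxygen. The step is only a floor, as compound 1 stands at a limit: the limit of > 200000 nM in this assay, at which 1 of the 4 values shown sits.

Still open, from the compounds shown here alone, is how a pyridine ring in place of the phenyl ring of the phenethyl group would read. Also open, going by these compounds, is what an amine or a carboxylic acid at the end of the chain would do.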